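A few compounds are considered here, and "the series" means these few. Any claim that something is new, unique, unknown or untested is made for them only; others in the source may bear on it.

Measured compounds and their values:

- Compound 1, `O=C(Nc1ccccc1)c1cc2n(n1)CCCN(C(=O)c1ccco1)C2`: in an ADME assay on BEAS-2B cells (Homo sapiens) for cytotoxicity, read by fluorescence, with a stated time of 48 h (on this read-out lower numbers stand for higher toxicity in this test and higher numbers for lower toxicity in this test), compound 1 gives "not determined" (no result reported)
- Compound 2, `Cc1ccoc1C(=O)N1CCCn2nc(C(=O)Nc3ccc(F)cc3F)cc2C1`: in this assay compound 2 gives 5000 nM
- Compound 3, `Cc1ccoc1C(=O)N1CCCn2nc(C(=O)Nc3ccc(F)cc3)cc2C1`: in this assay compound 3 gives 90000 nM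

Compounds 2 and 3 share one core and differ in a single place. The change from compound 3 to compound 2 is fluoro in place of hydrogen on an aromatic carbon. In this assay this change made a step of an 18-fold lower number from compound 3 to compound 2 (1.26 log units; beyond the scatter), so the compound carrying the extra fluoro turned out to be the more toxic of the two.

Compound 4, `O=C(Nc1ccccc1F)c1cc2n(n1)CCCN(C(=O)c1ccco1)C2`, has not yet been measured. It is related to compound 1 by the same kind of change: fluoro in place of hydrogen on an aromatic carbon. The surroundings are not identical, though. In the step from compound 3 to compound 2 the new fluoro sits ortho to a large group and meta to a fluoro group, whereas in compound 4 it sits ortho to a large group only. The difference between the core of compound 1 and the core of compound 3 is not broken down here.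

Compound 1 has no number in this assay. The expectation for compound 4 therefore cannot be built as a step from compound 1; it rests on compound 2 and compound 3 alone. Compound 2, which carries the fluoro in the same kind of place, gave 5000 nM, and that value is the main anchor. For compound 4 the expected result in this assay is 15000 nM. The estimated range for compound 4 runs from 3000 nM to 80000 nM.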

Compound 4, half-maximal cytotoxic concentration: 3700 nM
Estimate against measurement, compound 4: 4.1-fold (0.61 log units) above, within the range that was stated.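

In this assay compound 1 gives "not determined" (no result reported), so no new step can be read between compound 1 and compound 4. As far as these compounds go, whether fluoro in place of hydrogen on the core of compound 1 brings a change like an 18-fold lower number from compound 3 to compound 2 (1.26 log units; beyond the scatter) stays open. Nothing shown here offers an explanation for these values.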